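This account rests on a few compounds, and the source may have more. Where it says the series, first, only, none or still open, it means among the compounds named here.

Measured so far in a functional assay on KM12 cells (Homo sapiens) for cytotoxicity, read by resazurin assay, with a stated time of 72 h; a higher number here means a weaker inhibitor, a lower number a stronger inhibitor:
- compound 1 `COc1ccc(Nc2ncnc3ccsc23)cc1`: 103000 nM
- compound 2 `Fc1ccc(Nc2ncnc3ccsc23)cc1`: 133000 nM

Compound 2 stands level with compound 1, with no gap beyond the scatter. Compound 3 `O=C(c1ccc(Nc2ncnc3ccsc23)cc1)N1CCCCC1` is not yet measured. It carries (piperidin-1-yl)carbonyl in place of fluoro on an aromatic carbon, para to a large group: (piperidin-1-yl)carbonyl in place of fluoro on an aromatic carbon. Among the compounds with values here, only one measured step bears on this change, a 1.3-fold higher number from compound 1 to compound 2 (0.11 log units; within the scatter). Within the data shown here, that step exchanges fluoro and methoxy only, and no measured compound carries the entering group, so it is a weak guide. With nothing beyond it, no shift past the scatter is expected in this assay, and no direction is favoured. The expected step is a 1.3-fold lower number from compound 2 to compound 3 (0.12 log units; within the scatter). The estimate for compound 3 is 100000 nM, with an expected range of 30000 nM to 250000 nM.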

Compound 3, half-maximal inhibitory concentration: 150000 nM
Estimate against measurement, compound 3: 1.5-fold (0.18 log units) below; the range from low to high includes it.
By their numbers in this assay, from the lowest: compounds 1, 2 and 3 (each within the scatter of the next).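

In this assay, (piperidin-1-yl)carbonyl in place of fluoro gives a 1.1-fold higher number from compound 2 to compound 3 (0.05 log units; within the scatter), and in place of methoxy it gives a 1.5-fold higher number from compound 1 to compound 3 (0.16 log units; within the scatter). The aromatic carbon therefore now carries a group of 8 heavy atoms, with a six-membered non-aromatic ring and a carbonyl, and the read-out still shows no step beyond the scatter, so the range of groups compared here is much wider than the exchange of fluoro and methoxy alone. No accompanying measurement bears on this result.

Going by these compounds, whether an amine or a carboxylic acid on this carbon would give a step beyond the scatter remains open. On these data alone, it is also open whether any change to the shared core, rather than to this position, would do so.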